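Capping the Hydroxyl: From Compound 2 to Compound 3

The source may hold more compounds than are shown below. What is called first, only, known or untested is meant among the compounds shown, and "the series" means these compounds.

Compound 1 `NC[C@@H]1CCCc2cc(S(=O)(=O)c3cccc(F)c3)ccc21`: in an assay on isolated protein for displacement of a labelled ligand from 5-hydroxytryptamine receptor 6 (Homo sapiens) (a lower number here means a stronger inhibitor, a higher number a weaker inhibitor), compound 1 gives 0.0794 nM
Compound 2 `O=S(=O)(c1cccc(F)c1)c1ccc2c(c1)CCC[C@H]2CNCCO`: in this assay compound 2 gives 0.126 nM

Among the compounds with values here, compound 2 has the higher of the two numbers measured so far, and its nearest neighbour is compound 1; the step of a 1.6-fold higher number from compound 1 to compound 2 (0.20 log units; within the scatter) lies within the scatter, so the two compounds cannot be ordered on these data. Compound 3 `COCCNC[C@@H]1CCCc2cc(S(=O)(=O)c3cccc(F)c3)ccc21` differs from compound 2 by methyl in place of hydrogen on an oxygen on a saturated carbon. Within the data shown here, no measured step concerns a change at this oxygen. Among the measured compounds shown here, the only step available, a 1.6-fold higher number from compound 1 to compound 2 (0.20 log units; within the scatter), concerns the substituent on the amine nitrogen and stayed within the scatter, so the numbers give no indication that alterations in this part of the molecule move the read-out far. The expectation for compound 3 is therefore a step of a 1.2-fold higher number from compound 2 to compound 3 (0.08 log units; within the scatter) that does not exceed the scatter, in either direction. Compound 3 is estimated at 0.15 nM, with a range from 0.05 nM to 0.5 nM.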

Compound 3, inhibition constant: 0.251 nM
Compound 3: the middle estimate sits 1.7-fold (0.22 log units) below what was measured; measured number inside the range.
By their numbers in this assay, from the lowest: compounds 1, 2 and 3 (each within the scatter of the next, the first and the last beyond it).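

In this assay the methyl on this oxygen gives a step that stays within the scatter (a 2.0-fold higher number from compound 2 to compound 3 (0.30 log units; within the scatter)), so hydroxy and methoxy cannot be told apart at this position. Measured against the unsubstituted amine of compound 1, however, the 2-methoxyethyl group gives a modest step beyond the scatter (a 3.2-fold higher number from compound 1 to compound 3 (0.50 log units; beyond the scatter)), whereas the 2-hydroxyethyl group stayed within it (a 1.6-fold higher number from compound 1 to compound 2 (0.20 log units; within the scatter)). Within the data shown here, this is the first step to leave the scatter, though the two substituents on the nitrogen still cannot be separated from each other.

The compounds shown leave open whether a larger group on this oxygen, such as ethyl or benzyl, would carry the number further from that of compound 1. They also leave open how a carboxylic acid or a second amine at the end of the chain would read. No measurement shown here accounts for these steps.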